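Side-Chain Amine Changes and Antiproliferative Potency

The source may report more compounds than this note shows. Statements on the series, on what has been measured and on what is new or still open speak of the compounds shown alone.

Compound 1 `CN(C)CCCn1c(N)c(-c2nc3cc(Cl)ccc3[nH]2)c2nc(C#N)c(C#N)nc21`: 2930 nM
Compound 2 `CCN(CC)CCCn1c(N)c(-c2nc3cc(Cl)ccc3[nH]2)c2nc(C#N)c(C#N)nc21`: 3470 nM
Compound 3 `CN(C)CCCCn1c(N)c(-c2nc3cc(Cl)ccc3[nH]2)c2nc(C#N)c(C#N)nc21`: 1480 nM

All three were tested in a functional assay on HL-60 cells (Homo sapiens) for antiproliferative activity, read by MTT assay, with a stated time of 48 h; a lower number here means a stronger inhibitor, a higher number a weaker inhibitor. Compound 1 and compound 2 are separated by diethylamino in place of dimethylamino on a saturated chain carbon, three bonds along the chain from an aromatic nitrogen, a change that gave a 1.2-fold higher number from compound 1 to compound 2 (0.07 log units; within the scatter). Compound 3 differs from compound 1 by (dimethylamino)methyl in place of dimethylamino on a saturated chain carbon, three bonds along the chain from an aromatic nitrogen and gave a 2.0-fold lower number from compound 1 to compound 3 (0.30 log units; within the scatter); against compound 2 it gave a 2.3-fold lower number from compound 2 to compound 3 (0.37 log units; beyond the scatter).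

Compound 4 `CCN(CC)CCCCn1c(N)c(-c2nc3cc(Cl)ccc3[nH]2)c2nc(C#N)c(C#N)nc21` has not yet been measured in this assay. It differs from compound 3 by diethylamino in place of dimethylamino on a saturated chain carbon, four bonds along the chain from an aromatic nitrogen. This is the same kind of change as that from compound 1 to compound 2, but not the same: there the place is on a saturated chain carbon three bonds along the chain from an aromatic nitrogen, here four bonds along the chain. The earlier step gave a 1.2-fold higher number from compound 1 to compound 2 (0.07 log units; within the scatter). For compound 4 a step of similar size is expected, a 1.2-fold higher number from compound 3 to compound 4 (0.07 log units; within the scatter), resting on the fact that compound 3 gives 1480 nM. Compound 4 is therefore estimated at 1750 nM, most likely between 900 nM and 3500 nM.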

Compound 4, half-maximal inhibitory concentration: 820 nM
Compound 4: middle estimate off by 2.1-fold (0.33 log units), on the high side, and the stated range ends above it.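

In this assay the change from dimethylamino to diethylamino on the longer chain gave a 1.8-fold lower number from compound 3 to compound 4 (0.26 log units; within the scatter) and, set beside the same change on the shorter chain, shows no difference between the two cores: the same change on two cores in this assay, a 1.2-fold higher number (0.07 log units; within the scatter) from compound 1 to compound 2 and a 1.8-fold lower number (0.26 log units; within the scatter) from compound 3 to compound 4, 2.1-fold (0.33 log units) apart, within the scatter of two such steps. The change therefore carried across this one pair of cores without a detectable shift, but two steps that both lie within the scatter do not show that it would carry to other cores. The steps of a 4.2-fold lower number from compound 2 to compound 4 (0.63 log units; beyond the scatter) and a 3.6-fold lower number from compound 1 to compound 4 (0.55 log units; beyond the scatter) lie beyond the scatter, yet they include the change in chain and do not speak to the amine change alone.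

The compounds shown leave open whether a cyclic amine such as pyrrolidine or morpholine, or a still longer chain, would follow the same course.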